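The source may report more compounds than this note shows. Statements on the series, on what has been measured and on what is new or still open speak of the compounds shown alone.

Measured so far in a functional assay on L1210 cells (Mus musculus); a lower number here means a stronger inhibitor, a higher number a weaker inhibitor:
compound 1 `CCCNC(=O)Nc1ccc(C(C)(C)C)cc1` gives 5400 nM
compound 2 `CCC(C)c1ccc(NC(=O)NC)cc1` gives 62000 nM

Compound 2 holds the higher, weaker of these two numbers, and its gap to compound 1 lies beyond the scatter. Compound 3 `CNC(=O)Nc1ccc(C(C)(C)C)cc1` is not yet measured. It has the same atoms as compound 2, joined differently: tert-butyl in place of sec-butyl on an aromatic carbon. For the measured compounds named here, no step between measured compounds shows what such a swap does in this assay, so the data offer no direct guide to its size. Only a modest step is expected, towards a lower number, and it may well stay within the scatter. The expected change is a 1.8-fold lower number from compound 2 to compound 3 (0.25 log units; within the scatter). Compound 3 is estimated at 35000 nM, with an expected range of 12000 nM to 90000 nM.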

Compound 3, half-maximal inhibitory concentration: 80000 nM
For compound 3 the middle estimate is 2.3-fold (0.36 log units) below the measured one; the measured number falls inside the stated range.
By their numbers in this assay, from the lowest: compound 1; then compounds 2 and 3 (each within the scatter of the next).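

In this assay, tert-butyl in place of sec-butyl on an aromatic carbon para to a (methylcarbamoyl)amino group gives a 1.3-fold higher number from compound 2 to compound 3 (0.11 log units; within the scatter), so these two butyl groups are not separated at this position. Hydrogen in place of ethyl on a saturated chain carbon bound to an amide-type nitrogen gives a 15-fold higher number from compound 1 to compound 3 (1.17 log units; beyond the scatter), a large step with the tert-butyl group held fixed. The gap between compound 1 and compound 2 therefore goes with this chain change, not with the choice of butyl group. Nothing available bears on why either step has this size. Still open, on these data alone, is whether a longer chain, or an amine or carboxylic acid on that chain, extends the gain seen with ethyl. Also open, as far as these compounds go, is whether a trifluoromethyl group or a chlorine atom in place of tert-butyl would remain equally indistinct.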